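A few compounds are considered here, and "the series" means these few. Any claim that something is new, unique, unknown or untested is made for them only; others in the source may bear on it.

Compound 1 `Cc1nn(-c2ccccc2)c2nc(OCc3ccccc3F)c(-c3nc(N)c(N4CCOC4=O)c(N)n3)cc12` and compound 2 `Cc1nn(-c2ccccc2)c2nc(OCc3cccc(F)c3)c(-c3nc(N)cc(N)n3)cc12` were both tested in a functional assay on aorta (Rattus norvegicus, strain Sprague-Dawley); on this read-out higher numbers stand for an effect only at larger amounts of compound and lower numbers for an effect already at smaller amounts. Compound 1 reads > 100000 nM, which is a limit of the assay and not a number. Going by the values given here, compound 2 gives 360 nM, the only true number available in this assay, and so it is the sole reference point for what follows.

Compound 3 `Cc1nn(-c2ccccc2)c2nc(OCc3ccc(C(F)(F)F)cc3)c(-c3nc(N)cc(N)n3)cc12` keeps the shared core of compound 2 and alters one group: 4-(trifluoromethyl)phenyl in place of 3-fluorophenyl on a saturated chain carbon bound to an oxygen on an aromatic ring. In words, 4-(trifluoromethyl)phenyl stands in place of 3-fluorophenyl on a saturated chain carbon bound to an oxygen on an aromatic ring. Among the compounds with values here, no measured pair shows what a change at this place does, so any forecast is cautious and starts from compound 2 at 360 nM. A modest shift towards needing larger amounts of compound is expected, though a result within the usual scatter would not be surprising. The estimated change is a 2.2-fold higher number from compound 2 to compound 3 (0.35 log units; beyond the scatter). For compound 3 the expected value in this assay is 800 nM, with an estimated range of 150 nM to 5000 nM.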

Compound 3, half-maximal effective concentration: 1600 nM
For compound 3 the middle estimate is 2.0-fold (0.30 log units) below the measured one, within the range that was stated.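

In this assay, going by these compounds alone, putting 4-(trifluoromethyl)phenyl in place of 3-fluorophenyl on a saturated chain carbon bound to an oxygen on an aromatic ring gives a 4.4-fold higher number from compound 2 to compound 3 (0.65 log units; beyond the scatter) and so provides the first measured step at this position. The position is therefore not indifferent to the group it carries, yet the change does not abolish the read-out: compound 3 gives 1600 nM as a true number and not a limit of the assay. Within the data shown here, nothing given here accounts for the step, since the only supporting information concerns a limit reached by another compound.

Among these compounds, the single step changes the substituent and its place on the phenyl ring together, with the group growing from 7 to 10 heavy atoms, so the contribution of each change remains unresolved. Going by these compounds, it also remains open how 3-(trifluoromethyl)phenyl, 4-fluorophenyl or unsubstituted phenyl would read at this position, and whether a phenyl ring carrying an amine or a carboxylic acid would follow the same direction.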